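Removing the hydroxymethyl from compound 3

The source may hold more compounds than are shown below. What is called first, only, known or untested is meant among the compounds shown, and "the series" means these compounds.

Compound 3 `O=C(O)CC/C=C\CO[C@H]1[C@@H](OCc2ccc(-c3ccccc3CO)cc2)CC[C@@H]1N1CCCCCC1` gives 1.59 nM in a functional assay on blood for antagonist activity at thromboxane A2 receptor (Homo sapiens) (a lower number here means tighter binding, a higher number weaker binding), the lowest number among the compounds with a value here; the nearest is compound 2 `O=C(O)CC/C=C\CO[C@H]1C(OCc2ccc(-c3ccccc3)cc2)CC[C@@H]1N1CCCCCC1` at 12.6 nM, a gap well beyond the scatter. Compound 1 `O=C(O)CC/C=C\CO[C@H]1[C@@H](OCc2ccc(-c3ccccc3)cc2)CC[C@@H]1N1CCCCC1` gives 10 nM; 7.94 nM (2 entries), and the spread between its entries is small (the several entries of compound 1 in this assay, 10 nM; 7.94 nM (2 entries)). Compound 3 carries a hydroxymethyl on its outer phenyl ring; compound 1 and compound 2 do not, and both sit at the weaker end.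

Compound 4 `O=C(O)CC/C=C\CO[C@H]1[C@@H](OCc2ccc(-c3ccccc3)cc2)CC[C@@H]1N1CCCCCC1` has not yet been measured. From compound 3 the change is hydrogen in place of hydroxymethyl on an aromatic carbon. Going by the values given here, no step between measured compounds is available for this change, so the expectation rests on the values of compound 1 and compound 2, which lack the hydroxymethyl and give higher numbers than compound 3. A weakening of binding is expected, and the step from compound 3 to compound 4 is estimated at a 6.3-fold higher number from compound 3 to compound 4 (0.80 log units; beyond the scatter), beyond the scatter. Compound 4 is expected to give 10 nM in this assay, within 4 nM to 25 nM.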

Compound 4, dissociation constant: 5.01 nM
For compound 4 the middle estimate is 2.0-fold (0.30 log units) above the measured one; the range from low to high includes it.
By their numbers in this assay, from the lowest: compound 3; then compound 4; then compound 2.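

Going by these compounds alone, the first direct pair at this place gives a size to the 2-(hydroxymethyl)phenyl to phenyl change: in this assay it is a 3.2-fold higher number from compound 3 to compound 4 (0.50 log units; beyond the scatter). The hydroxymethyl thus gives a modest gain, and the plain phenyl of compound 4 is not required to carry it for binding to remain tight. The second new pair gives a 2.5-fold lower number from compound 2 to compound 4 (0.40 log units; beyond the scatter), a step that concerns stereochemistry rather than the outer ring and says only that the drawings differ at one stereocentre: the fact that one of compounds 2 and 4 is drawn with a defined configuration and the other without, at the place where they differ.

The compounds shown leave open whether a methyl, a methoxymethyl or a carboxylic acid on this aromatic carbon would give a number nearer that of compound 3 or that of compound 4. They also leave open whether the hydroxymethyl step carries over to the ring amine of compound 1.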